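The compounds below may be only part of what the source reports. "The series", "measured", "known", "first", "only" and "open" are said of these compounds alone.

Working notes on the series, all read in a functional assay on HepG2 cells (Homo sapiens) for antiproliferative activity, read by MTT assay, with a stated time of 24 h; on this read-out higher numbers stand for weaker inhibition and lower numbers for stronger inhibition. Compound 1 `COc1ccc(C(=O)/C=C/c2cccc(F)c2)c2c1C=CC(C)(C)O2` reads > 10000 nM, which is a limit of the assay and not a number. Compound 2 `COc1ccc(C(=O)/C=C/c2ccc([N+](=O)[O-])cc2)c2c1C=CC(C)(C)O2` gives 2610 nM. Compound 3 `COc1ccc(C(=O)/C=C/c2ccccn2)c2c1C=CC(C)(C)O2` gives 5760 nM, the higher of the two actual numbers, and so sits above compound 2.

Next comes compound 4 `COc1ccc(C(=O)/C=C/c2ccc(O)cc2)c2c1C=CC(C)(C)O2`, with 4-hydroxyphenyl in place of pyridin-2-yl on a double-bonded chain carbon bound to a double-bonded chain carbon.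

For the measured compounds named here, three measured steps bear on this place: an at least 3.8-fold lower number from compound 1 to compound 2 (0.58 log units; beyond the scatter), an at least 1.7-fold lower number from compound 1 to compound 3 (0.23 log units; that floor lies within the scatter) and a 2.2-fold higher number from compound 2 to compound 3 (0.34 log units; beyond the scatter). They show that swaps here have moved the number modestly or more, in the case of the first step, and modestly between the two exact values. Going by the values given here, none of the measured compounds carries a hydroxyl group, so no step isolates this change, and its direction cannot be read from the series.

No shift beyond the scatter is therefore expected, and the expected step is a 1.2-fold lower number from compound 3 to compound 4 (0.06 log units; within the scatter). Compound 4 is estimated at 5000 nM, with an expected range of 1800 nM to 10000 nM.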

Compound 4, half-maximal inhibitory concentration: > 10000 nM
Compound 4 was reported as a limit (the forecaster's own chance of this, stated with the estimate: 25%); at least 2.0-fold (0.30 log units) between middle value and limit.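

Hydroxy in place of nitro on an aromatic carbon gives an at least 3.8-fold higher number from compound 2 to compound 4 (0.58 log units; beyond the scatter), the first step at this place that keeps the ring and the position of its substituent and changes only the substituent itself. The swap from pyridin-2-yl gives an at least 1.7-fold higher number from compound 3 to compound 4 (0.23 log units; that floor lies within the scatter), a floor that does not show 4-hydroxyphenyl and pyridin-2-yl to differ beyond the scatter. Compound 4 is reported as a limit of the assay, so both of these steps are floors, and the step from compound 1 cannot be read: the limit of > 10000 nM in this assay, at which 2 of the 4 values shown sit.

On these data alone, the true size of the hydroxy step stays open, as does the question of whether the lower number of compound 2 is tied to nitro in particular or would also appear with other groups at the same ring position. How a 4-aminophenyl or a 4-carboxyphenyl group on the same double-bonded chain carbon would read remains unknown from the compounds shown, and so does any effect of moving nitro or hydroxy elsewhere on the ring.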